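The source may report more compounds than this note shows. Statements on the series, on what has been measured and on what is new or still open speak of the compounds shown alone.

Compound 1 `Nc1cccc(/C=C2\SC(=O)N(Cc3ccc(F)cc3)C2=O)c1` is examined in a functional assay on FM3A cells (Mus musculus) for cytotoxicity, read by cell counting, with a stated time of 2 days (on this read-out lower numbers stand for stronger inhibition and higher numbers for weaker inhibition), where compound 1 gives 140000 nM, the highest of the two numbers that this assay has produced. Compound 3 `Nc1ccc(/C=C2\SC(=O)N(Cc3ccc(F)cc3)C2=O)cc1` gives 36000 nM in this assay, so that a 3.9-fold lower number from compound 1 to compound 3 (0.59 log units; beyond the scatter). Compound 2 `Nc1cccc(/C=C2\SC(=O)N(Cc3cccc(F)c3)C2=O)c1` reaches only a limit of this assay, > 250000 nM (the limit of > 250000 nM in this assay, at which 1 of the 3 values shown sits). The corresponding step, an at least 1.7-fold higher number from compound 1 to compound 2 (0.25 log units; that floor lies within the scatter), alters the fluorophenyl group, the same group changed in compound 4 `Nc1cccc(/C=C2\SC(=O)N(Cc3ccc(C(F)(F)F)cc3)C2=O)c1`, which differs from compound 1 by trifluoromethyl in place of fluoro on an aromatic carbon. That earlier step gives no clear direction, so no step beyond the scatter is expected here, a 1.1-fold higher number from compound 1 to compound 4 (0.03 log units; within the scatter). Compound 4 is therefore estimated at 150000 nM in this assay, with a range from 50000 nM to 400000 nM.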

Compound 4, half-maximal inhibitory concentration: > 250000 nM
Compound 4 gave a limit, no number; the forecaster's own chance of this, stated with the estimate: 35%; at least 1.6-fold (0.22 log units) between middle value and limit.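

In this assay the change from fluoro to trifluoromethyl on this aromatic carbon, para to a large group, leaves compound 4 with a limit rather than a number, and the step is an at least 1.7-fold higher number from compound 1 to compound 4 (0.25 log units; that floor lies within the scatter). On these data alone, its true size therefore stays unknown, and its floor alone shows no change beyond the scatter. Two changes to the fluorophenyl group of compound 1 now end at the same limit, so this position yields no further number for comparison: the limit of > 250000 nM in this assay, at which 2 of the 4 values shown sit.

As far as these compounds go, it remains open whether chloro, methoxy or an amine on this aromatic carbon would give a number within range. From the compounds shown here alone, it is also open whether trifluoromethyl would behave the same way on the 4-aminophenyl series of compound 3.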